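The source may hold more compounds than are shown below. What is called first, only, known or untested is meant among the compounds shown, and "the series" means these compounds.

Measured compounds in a functional assay on PC-3 cells (Homo sapiens) for cytotoxicity, read by MTT assay, with a stated time of 72 h; a lower number here means a stronger inhibitor, a higher number a weaker inhibitor:
compound 1 `CCCCCCNc1nc(SCc2ccc(C(F)(F)F)cc2)nc2ccccc12`, 19000 nM
compound 2 `CCCCCCCCNc1nc(SCc2ccc(C(F)(F)F)cc2)nc2ccccc12`, 10500 nM
compound 3 `CCCCCCCCCCCCNc1nc(SCc2ccc(C(F)(F)F)cc2)nc2ccccc12`, 26000 nM

Compound 3 has the highest of the three numbers in this assay. Its nearest neighbour is compound 1, with a 1.4-fold higher number from compound 1 to compound 3 (0.14 log units; within the scatter), a step within the scatter; its furthest is compound 2, with a 2.5-fold higher number from compound 2 to compound 3 (0.39 log units; beyond the scatter), a modest step beyond the scatter. Compound 4 `CCCCCCCCCCCCCCNc1nc(SCc2ccc(C(F)(F)F)cc2)nc2ccccc12` is not yet measured. It differs from compound 3 by ethyl in place of hydrogen on a saturated chain carbon, ten or more bonds along the chain from a nitrogen on an aromatic ring.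

Going by the values given here, the steps that bear on this change all lengthen the same chain: a 1.8-fold lower number from compound 1 to compound 2 (0.26 log units; within the scatter) and a 1.4-fold higher number from compound 1 to compound 3 (0.14 log units; within the scatter) stay within the scatter, while a 2.5-fold higher number from compound 2 to compound 3 (0.39 log units; beyond the scatter) lies beyond it. Taken together they give no firm direction for a further short extension; if anything the longest chain so far carries the highest number. Compound 4 is therefore expected to land close to compound 3, with at most a small rise, estimated as a 1.2-fold higher number from compound 3 to compound 4 (0.09 log units; within the scatter). Compound 4 is estimated at 32000 nM, within a range of 12000 nM to 80000 nM.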

Compound 4, half-maximal inhibitory concentration: > 50000 nM
Compound 4 ended at the assay's limit (the forecaster's own chance of this, stated with the estimate: 20%); at least 1.5-fold (0.19 log units) between middle value and limit.
By their numbers in this assay, from the lowest: compounds 2, 1 and 3 (each within the scatter of the next, the first and the last beyond it). At a limit, above all of these: compound 4.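

In this assay, compound 4 gives > 50000 nM, which is a limit of the assay and not a number. The limit separates this longest chain from the two shorter ones, with an at least 4.7-fold higher number from compound 2 to compound 4 (0.67 log units; beyond the scatter) and an at least 2.6-fold higher number from compound 1 to compound 4 (0.42 log units; beyond the scatter), whereas an at least 1.9-fold higher number from compound 3 to compound 4 (0.28 log units; that floor lies within the scatter) gives only a floor that does not by itself separate it from compound 3. Lengthening the chain therefore does not have one constant outcome across the series, since the same added ethyl or hexyl gives different steps depending on the chain it extends: the same change on two cores in this assay, a 1.8-fold lower number (0.26 log units; within the scatter) from compound 1 to compound 2 and an at least 1.9-fold higher number (0.28 log units; that floor lies within the scatter) from compound 3 to compound 4, at least 3.4-fold (0.54 log units) apart, beyond the scatter of two such steps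

From the compounds shown here alone, how far the true value of compound 4 lies past the limit stays open. Also open, going by these compounds, is whether a chain ending in an amine or a carboxylic acid, at the same place on the core, would keep the number of compound 2.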